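Methylating the Ring Nitrogen of Compound 2

The source may hold more compounds than are shown below. What is called first, only, known or untested is meant among the compounds shown, and "the series" means these compounds.

Compound 1 `N#Cc1c(-c2ccc(Cl)cc2)nc(SCC(=O)Nn2c(COc3ccc(Cl)cc3Cl)nc3ccccc3c2=O)[nH]c1=O` gives 64.9% in a functional assay on the whole organism (strain albino) for inhibition, with Rattus norvegicus as the target, read by paw edema, with stated times of 1 h and 3 h, at a dose of 100 mg/kg by the oral route; on this read-out higher numbers stand for a stronger effect at the one dose given and lower numbers for a weaker effect.
Compound 2 `N#Cc1c(-c2ccc(O)cc2)nc(SCC(=O)Nn2c(COc3ccc(Cl)cc3Cl)nc3ccccc3c2=O)[nH]c1=O` gives 68.4%.
Compound 3 `O=C(CSc1nc(-c2ccc(O)cc2)c(C(=O)O)c(=O)[nH]1)Nn1c(COc2ccc(Cl)cc2Cl)nc2ccccc2c1=O` gives 38.6%.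

Compound 2 carries the highest of the three numbers shown, yet a number 3.5 percentage points higher from compound 1 to compound 2 (within the scatter) lies within the scatter, so compounds 1 and 2 cannot be told apart; only a number 29.8 percentage points lower from compound 2 to compound 3 (beyond the scatter) stands beyond it. Compound 4 `Cn1c(SCC(=O)Nn2c(COc3ccc(Cl)cc3Cl)nc3ccccc3c2=O)nc(-c2ccc(O)cc2)c(C#N)c1=O` differs from compound 2 by methyl in place of hydrogen on an aromatic nitrogen. Among the compounds with values here, neither measured step touches this ring nitrogen, and the one change on the shared core, a number 29.8 percentage points lower from compound 2 to compound 3 (beyond the scatter), exchanged a different group on a ring carbon. Within the data shown here, with no direct precedent, a step of at most modest size is expected, with no clear direction, so the uncertainty stays wide. Compound 4 is therefore estimated at 60%, between 42% and 76%, which would mean an expected step of a number 8.4 percentage points lower from compound 2 to compound 4 (within the scatter).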

Compound 4, a percentage reported as inhibition, in the whole organism at one dose (the size of the read-out at that dose, not a potency): 86%
For compound 4 the middle estimate is 26 percentage points below the measured one, outside the stated range (above it).
By their numbers in this assay, from the lowest: compound 3; then compounds 1 and 2 (each within the scatter of the next); then compound 4.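

Methyl in place of hydrogen on this ring nitrogen gives a number 17.6 percentage points higher from compound 2 to compound 4 (beyond the scatter) in this assay. The earlier steps, made elsewhere on the molecule, showed only a drop or no distinguishable change, so this is the first change shown that raises the number beyond the scatter, and the hydrogen on this nitrogen is not needed for the effect at this dose. No measurement here says why the number rises.

As far as these compounds go, whether a longer chain such as ethyl, or an amine-bearing chain, on this nitrogen would do the same remains open. So does whether methyl here would raise the numbers of compound 1 and compound 3.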